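The source may report more compounds than this note shows. Statements on the series, on what has been measured and on what is new or still open speak of the compounds shown alone.

Measured compounds:
- compound 1 `COc1ccc(-c2nn(-c3ccccc3)cc2C(=O)NOCc2ccccc2)cc1`; in a functional assay on HeLa cells (Homo sapiens) for antiproliferative activity, read by MTT assay, with a stated time of 48 h, in the presence of a further agent that is not named here (on this read-out higher numbers stand for weaker inhibition of growth and lower numbers for stronger inhibition of growth), compound 1 gives 2640 nM
- compound 2 `COc1ccc(-c2nn(-c3ccccc3)cc2C(=O)NOCc2ccccc2F)cc1`; in this assay compound 2 gives 2900 nM
- compound 3 `O=C(NOCc1ccccc1)c1cn(-c2ccccc2)nc1-c1ccc(F)cc1`; in this assay compound 3 gives 6110 nM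

Compound 4 `O=C(NOCc1ccccc1F)c1cn(-c2ccccc2)nc1-c1ccc(F)cc1` has not been measured. It differs from compound 3 in one place: fluoro in place of hydrogen on an aromatic carbon. The same change has already been made between two measured compounds, from compound 1 to compound 2: fluoro in place of hydrogen on an aromatic carbon. Both changes sit on the same kind of place, described in the same words, so the change is treated as the same. Its measured effect was a 1.1-fold higher number from compound 1 to compound 2 (0.04 log units; within the scatter), a step that does not rise out of the scatter.

The two cores differ as follows: fluoro in place of methoxy on an aromatic carbon. The core of compound 3 gave a 2.3-fold higher number from compound 1 to compound 3 (0.36 log units; beyond the scatter), a modest shift.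

For compound 4 the expected step in this assay is a 1.1-fold higher number from compound 3 to compound 4 (0.04 log units; within the scatter), resting on the earlier step of a 1.1-fold higher number from compound 1 to compound 2 (0.04 log units; within the scatter), which was essentially flat. Compound 4 is therefore estimated at 6700 nM, with a likely range from 3400 nM to 13000 nM.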

Compound 4, concentration for 50% growth inhibition: 10300 nM
Estimate against measurement, compound 4: 1.5-fold (0.19 log units) below, within the range that was stated.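

Benzyl to 2-fluorobenzyl gives a 1.7-fold higher number from compound 3 to compound 4 (0.23 log units; within the scatter) in this assay, and this step carries over from the core of compound 1 without a difference that rises out of the scatter: the same change on two cores in this assay, a 1.1-fold higher number (0.04 log units; within the scatter) from compound 1 to compound 2 and a 1.7-fold higher number (0.23 log units; within the scatter) from compound 3 to compound 4, 1.5-fold (0.19 log units) apart, within the scatter of two such steps

Fluoro in place of methoxy, read with 2-fluorobenzyl present, gives a 3.6-fold higher number from compound 2 to compound 4 (0.55 log units; beyond the scatter), and this agrees with the same change read with benzyl present: the same change on two cores in this assay, a 2.3-fold higher number (0.36 log units; beyond the scatter) from compound 1 to compound 3 and a 3.6-fold higher number (0.55 log units; beyond the scatter) from compound 2 to compound 4, 1.5-fold (0.19 log units) apart, within the scatter of two such steps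

Across these four compounds, the two changes therefore combine without a detectable interaction, but each comparison rests on a single pair of steps, and the fluoro step stays within the scatter on both cores, so this does not show that the step would hold on any further core or rule out a small difference between these two.

The compounds shown leave open whether an amine, a carboxylic acid or a trifluoromethyl group on the benzyl group would carry over between the two cores in the same way. They also leave open whether a step that rises clearly out of the scatter would transfer as closely as this one.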